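The source may hold more compounds than are shown below. What is called first, only, known or untested is meant among the compounds shown, and "the series" means these compounds.

Of the compounds shown here, three from one series have been tested in a functional assay on HEK293 cells (Homo sapiens) for inhibition; a higher number here means a weaker inhibitor, a lower number a stronger inhibitor. Compound 1 `CCCCCCCCCCCCS(=O)(=O)NCCCNC/C=C/CNCCCN` gives 522 nM. Compound 3 `CCCCCCCCCCCCS(=O)(=O)NCCNCCCNCCN` gives 686 nM, and compound 2 `CCCCCCCCS(=O)(=O)NCCNCCCNCCN` gives 13800 nM. The numbers for compound 1 and compound 3 lie within the usual scatter of each other, so nothing separates them.

Compound 2 and compound 3 differ in a single place, (hydrogen in place of butyl on a saturated chain carbon, eight bonds along the chain from a sulfonyl sulfur). That change brought a 20-fold higher number from compound 3 to compound 2 (1.30 log units; beyond the scatter). The difference between the core of compound 1 and the core of compound 3 is not broken down here.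

Compound 4 `CCCCCCCCS(=O)(=O)NCCCNC/C=C/CNCCCN` has not yet been measured in this assay. It stands to compound 1 exactly as compound 2 stands to compound 3, since it carries the same change at the same place, (hydrogen in place of butyl on a saturated chain carbon, eight bonds along the chain from a sulfonyl sulfur).

Because the same change produced a 20-fold higher number from compound 3 to compound 2 (1.30 log units; beyond the scatter), a step of about the same size is expected here, namely a 19-fold higher number from compound 1 to compound 4 (1.28 log units; beyond the scatter). Resting on that one observed step, compound 4 is estimated at 10000 nM, most likely between 4000 nM and 30000 nM.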

Compound 4, half-maximal inhibitory concentration: 12700 nM
Beside the measured number, compound 4's estimate is 1.3-fold (0.10 log units) below it, and the stated range covers the measured number.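

Replacing butyl with hydrogen on a saturated chain carbon, eight bonds along the chain from a sulfonyl sulfur, gave a 24-fold higher number from compound 1 to compound 4 (1.39 log units; beyond the scatter) in this assay. Set beside the earlier step, the change carried over from one core to the other at much the same size: the same change on two cores in this assay, a 20-fold higher number (1.30 log units; beyond the scatter) from compound 3 to compound 2 and a 24-fold higher number (1.39 log units; beyond the scatter) from compound 1 to compound 4, 1.2-fold (0.08 log units) apart, within the scatter of two such steps. Among these compounds, still, this is only two matched pairs, so it supports carrying the step between these two cores without showing that it would hold on any other core, and it does not explain why the shorter chain goes with the higher number.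

The compounds shown leave open what happens with a longer chain, or with a chain of a length that falls in the gap left by the two chains compared here. They also leave open whether the step would keep its size with an amide in place of the sulfonyl group.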